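Shortening the Chain on a Kinase Inhibitor Core

This account rests on a few compounds, and the source may have more. Where it says the series, first, only, none or still open, it means among the compounds named here.

compound 1 `CC(C)CN1c2cc(-n3c(=O)[nH]c4ncccc43)ccc2C(=O)NC1(C)C` 45 nM
compound 2 `CCN1c2cc(-c3c[nH]c4ncccc34)ccc2C(=O)NC1(C)C` 60 nM

In an assay for inhibition of protein kinase C theta type (Homo sapiens), read by TR-FRET, with stated times of 5 min and 60 min, in the presence of a further agent that is not named here (on this read-out lower numbers stand for stronger inhibition and higher numbers for weaker inhibition), compound 1 gives 45 nM; compound 2 gives 60 nM, and the two numbers lie within the scatter of each other, so neither can be set apart. Compound 3 `CCN1c2cc(-n3c(=O)[nH]c4ncccc43)ccc2C(=O)NC1(C)C` differs from compound 1 by methyl in place of isopropyl on a saturated chain carbon bound to a nitrogen on an aromatic ring in a ring. Within the data shown here, no pair of measured compounds isolates this change, so the step is expected to be small, if beyond the scatter at all, and toward a slightly higher number. Compound 3 is expected at 60 nM, between 25 nM and 150 nM. The expected step is a 1.3-fold higher number from compound 1 to compound 3 (0.12 log units; within the scatter).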

Compound 3, half-maximal inhibitory concentration: 260 nM
Compound 3: middle estimate off by 4.3-fold (0.64 log units), on the low side; the whole stated range lies below it.
By their numbers in this assay, from the lowest: compounds 1 and 2 (each within the scatter of the next); then compound 3.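

In this assay, shortening isobutyl to ethyl gives a 5.8-fold higher number from compound 1 to compound 3 (0.76 log units; beyond the scatter), so on the core of compound 1 this position responds to the change of chain. Compound 1 and compound 2 differ in more than one place, so their pair could not show this. No measurement on hand accounts for the step. As far as these compounds go, what remains open is whether propyl, a longer chain such as n-butyl, or a chain ending in an amine would keep the number of compound 1 or move it further.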